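A few compounds are considered here, and "the series" means these few. Any claim that something is new, unique, unknown or untested is made for them only; others in the source may bear on it.

In a physicochemical assay, with a stated time of 6 min (on this read-out higher numbers stand for weaker inhibition and lower numbers for stronger inhibition), compound 1 `O=C(Nc1ccc(F)cc1)Nc1nc(-c2cc3ccccc3o2)cs1`, which carries a fluoro group, gives 1130 nM. Compound 3 `O=C(Nc1ccc(Br)cc1)Nc1nc(-c2cc3ccccc3o2)cs1` stands at a limit, > 200000 nM, and so has no number of its own. Among the measured compounds shown here, the step of an at least 170-fold higher number from compound 1 to compound 3 (2.24 log units; beyond the scatter) is large, is the only measured step that bears on this position, and ends at the limit of > 200000 nM in this assay, at which 1 of the 3 values shown sits. Compound 4 `COc1ccc(NC(=O)Nc2nc(-c3cc4ccccc4o3)cs2)cc1` has methoxy in place of the bromo of compound 3, on an aromatic carbon: methoxy in place of bromo on an aromatic carbon. For the measured compounds named here, no measured step covers this exchange directly. The 4-methoxyphenyl group does occur on a different core in compound 2 `COc1ccc(NC(=O)Nc2nc(-c3cc4cc([N+](=O)[O-])ccc4o3)cs2)cc1`, which gives 121000 nM. Since compound 2 reads 121000 nM with this group, a sizeable move towards lower numbers is expected in this assay, although its size is uncertain. The expected step is an at least 10-fold lower number from compound 3 to compound 4 (1.00 log units; beyond the scatter). For compound 4 the estimated value is 20000 nM, with an expected range from 2000 nM to 150000 nM.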

Compound 4, half-maximal inhibitory concentration: 17400 nM
Beside the measured number, compound 4's estimate is 1.1-fold (0.06 log units) above it; the measured number falls inside the stated range.
By their numbers in this assay, from the lowest: compound 1; then compound 4; then compound 2. At a limit, above all of these: compound 3.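

In this assay, methoxy gives a number of its own at this position, where bromo gave only a limit (an at least 11-fold lower number from compound 3 to compound 4 (1.06 log units; beyond the scatter)), and that step is a bound rather than a measured size, as compound 3 stands at a limit of the assay: the limit of > 200000 nM in this assay, at which 1 of the 4 values shown sits. Methoxy still does not match fluoro on the same core (a 15-fold higher number from compound 1 to compound 4 (1.19 log units; beyond the scatter)), so the three groups now read in the order fluoro, methoxy, bromo, with bromo placed only by its limit. With the 4-methoxyphenyl group kept, a change elsewhere also moves the number, as hydrogen in place of nitro shows (a 7.0-fold lower number from compound 2 to compound 4 (0.84 log units; beyond the scatter)).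

The compounds shown leave open where chloro or an amine would fall at this position. They also leave open whether the same order holds on the nitro-bearing core, where only methoxy appears.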